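Removing a thiophen-2-yl group: what to expect

A few compounds are considered here, and "the series" means these few. Any claim that something is new, unique, unknown or untested is made for them only; others in the source may bear on it.

Compound 1 `CC(=O)NC(c1cccs1)c1cc(Cl)c2cccnc2c1O` and compound 2 `CCC(=O)NC(c1ccco1)c1cc(Cl)c2cccnc2c1O` share a core. In an assay for inhibition of Polyunsaturated fatty acid lipoxygenase ALOX12 (Homo sapiens), read by spectrophotometry (a higher number here means a weaker inhibitor, a lower number a stronger inhibitor), compound 1 gives 1000 nM and compound 2 gives 1000 nM, so compound 1 stands level with compound 2, within the usual scatter. Compound 3 `CC(=O)NCc1cc(Cl)c2cccnc2c1O` keeps that core and carries hydrogen in place of thiophen-2-yl on a saturated chain carbon bound to an amide-type nitrogen and an aromatic carbon. Within the data shown here, no measured pair shows what this change does, so any expectation rests on the size of the group that leaves. Compound 3 is expected to be a weaker inhibitor, estimated at 3000 nM with a range of 1000 nM to 10000 nM, which means an expected step of a 3.0-fold higher number from compound 1 to compound 3 (0.48 log units; beyond the scatter) beyond the scatter.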

Compound 3, half-maximal inhibitory concentration: > 150000 nM
Compound 3: only a limit was reported; the forecaster's own chance of this, stated with the estimate: 15%; middle value at least 50-fold (1.69 log units) from the limit.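

Putting hydrogen in place of thiophen-2-yl on this saturated chain carbon gives an at least 150-fold higher number from compound 1 to compound 3 (2.17 log units; beyond the scatter), so inhibition here depends heavily on what this carbon carries. For compound 3 the reading is a limit of the assay, not a number: the limit of > 150000 nM in this assay, at which 1 of the 3 values shown sits. Compounds 1 and 2 each keep a ring on this carbon, so neither could show what losing it does.

Still open, from the compounds shown here alone, is whether a ring is needed at all, or whether a simple methyl group or a longer chain on this carbon would also keep inhibition.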